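Adding a Second Chloro to the Triazole Aryl

This account rests on a few compounds, and the source may have more. Where it says the series, first, only, none or still open, it means among the compounds named here.

Two compounds share one core. Compound 1 `Cc1cn([C@H]2C[C@H](NC(=S)Nc3ccc(Cl)c(C(F)(F)F)c3)[C@@H](CO)O2)c(=O)[nH]c1=O` and compound 2 `Cc1cn([C@H]2C[C@H](n3cc(-c4ccc(Cl)cc4)nn3)[C@@H](CO)O2)c(=O)[nH]c1=O` were tested in an assay on isolated protein for inhibition of thymidine kinase 2, mitochondrial (Homo sapiens), read by scintillation counting, with a stated time of 30 min; on this read-out lower numbers stand for stronger inhibition and higher numbers for weaker inhibition. Compound 1 gives 150 nM, while compound 2 gives 46 nM, the lower of the two numbers, and that gap lies beyond the usual scatter. Compound 3 `Cc1cn([C@H]2C[C@H](n3cc(-c4ccc(Cl)c(Cl)c4)nn3)[C@@H](CO)O2)c(=O)[nH]c1=O` is not yet measured; it differs from compound 2 by chloro in place of hydrogen on an aromatic carbon. Within the data shown here, with no measured pair showing this change, only a small step is expected, toward a slightly lower number if any, within the scatter, so the step from compound 2 to compound 3 is estimated as a 1.3-fold lower number from compound 2 to compound 3 (0.12 log units; within the scatter). Compound 3 is therefore expected to give about 35 nM, between 12 nM and 100 nM.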

Compound 3, half-maximal inhibitory concentration: 42 nM
Estimate against measurement, compound 3: 1.2-fold (0.08 log units) below; the measured number falls inside the stated range.
By their numbers in this assay, from the lowest: compounds 3 and 2 (each within the scatter of the next); then compound 1.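

In this assay, among these compounds, the change from 4-chlorophenyl to 3,4-dichlorophenyl gives a 1.1-fold lower number from compound 2 to compound 3 (0.04 log units; within the scatter) and provides the first measured pair that differs in one place. A chloro on this aromatic carbon, ortho to a chloro group, is therefore accepted without a shift that stands out from the scatter. Nothing measured here accounts for this result. The compounds shown leave open how an amine, a carboxylic acid or a methoxy group would fare at this position. They also leave open whether the same chloro step would hold on a different aryl substitution.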